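Swapping the amine on the sulfonyl in a receptor agonist series

The compounds below may be only part of what the source reports. "The series", "measured", "known", "first", "only" and "open" are said of these compounds alone.

Measured compounds:
compound 1, `CN(c1ccccc1)S(=O)(=O)c1ccc(NC(=O)c2ccc(Cl)cc2Cl)cc1`, 50%
compound 2, `O=C(Nc1ccc(S(=O)(=O)Nc2ccccc2)cc1)c1ccc(Cl)cc1Br`, 123%
compound 3, `O=C(Nc1ccc(S(=O)(=O)Nc2ccccc2)cc1)c1ccc(C(F)(F)F)cc1F`, 50%

In a functional assay on HEK293 cells for agonist activity at probable G-protein coupled receptor 27 (Homo sapiens), read by a luciferase reporter and beta-arrestin recruitment, with a stated time of 10 min (a lower number here means a smaller maximal response, a higher number a larger maximal response), compound 1 reaches 50%. That places it level with compound 3, which in this assay gives 50%; the two are together the lowest of the three numbers and sit within the scatter of one another. Compound 2 is the furthest away, with 123% in this assay, a number that lies beyond the scatter above compound 1.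

The next compound, compound 4, `O=C(Nc1ccc(S(=O)(=O)Nc2ccccc2Cl)cc1)c1ccc(Cl)cc1Cl`, is not yet measured in this assay. It differs from compound 1 in one place: (2-chlorophenyl)amino in place of methyl(phenyl)amino on a sulfonyl sulfur. Among the measured compounds shown here, no step between two measured compounds follows this exact change, so the expectation must rest on what the three numbers show. Compounds 2 and 3 both carry an amino group on the sulfonyl sulfur, and their values span the whole range seen here, from the level of compound 1 up to the highest number. The account therefore expects a rise from compound 1 to compound 4 of moderate size, a number 30 percentage points higher from compound 1 to compound 4 (beyond the scatter), with a wide margin. For compound 4 the estimated maximal response in this assay is 80%, expected to lie between 45% and 125%.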

Compound 4, largest response reached (Emax), in percent of the reference or control that the assay uses: 53%
Estimate against measurement, compound 4: 27 percentage points above; the range from low to high includes it.
By their numbers in this assay, from the lowest: compounds 1, 3 and 4 (each within the scatter of the next); then compound 2.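

Among the compounds shown here, this is the first direct step at the amine on the sulfonyl sulfur: in this assay, (2-chlorophenyl)amino in place of methyl(phenyl)amino gives a number 3 percentage points higher from compound 1 to compound 4 (within the scatter). The maximal response therefore stays within the scatter, even though the entering group carries a hydrogen-bond donor that the leaving group lacks and brings a chlorine while losing a methyl. This single step bundles those differences together, and nothing available explains the outcome or separates their contributions.

The compounds shown leave open whether either difference matters on its own or whether the two offset each other, a question that phenylamino on the core of compound 1 would help to settle. They also leave open how far this position tolerates other amines, such as piperidine, morpholine or benzylamino, and the pair of compound 4 and compound 2, which differ in more than one place, cannot show whether any change on the sulfonyl sulfur reaches the higher response that compound 2 gives, 123%.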